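Pendant Phenyl Substituent Swap in the Benzothiazole Series

The compounds below may be only part of what the source reports. "The series", "measured", "known", "first", "only" and "open" are said of these compounds alone.

Compound 1 `Cc1ccc(-c2ccc(C)n2-c2ccc(-c3nc4ccc(F)cc4s3)cc2)cc1` and compound 2 `Cc1ccc(-c2ccc(F)cc2)n1-c1ccc(-c2nc3ccc(F)cc3s2)cc1` share one core and differ at a single aromatic carbon, where compound 2 carries fluoro in place of methyl. In a functional assay on MDA-MB-231 cells (Homo sapiens) for cytotoxicity, read by sulforhodamine B assay, with a stated time of 48 h (on this read-out lower numbers stand for stronger inhibition of growth and higher numbers for weaker inhibition of growth), compound 1 gives 3140 nM and compound 2 gives 3030 nM. The step of a 1.0-fold lower number from compound 1 to compound 2 (0.02 log units; within the scatter) shows that this exchange left the read-out essentially unchanged. Among the compounds with values here, compound 2 holds the lowest of the two numbers, yet its only neighbour, compound 1, sits within the scatter, so no order between them can be claimed.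

Compound 3 `COc1ccc(-c2ccc(C)n2-c2ccc(-c3nc4ccc(F)cc4s3)cc2)cc1` has not yet been measured. Relative to compound 2 the change is methoxy in place of fluoro on an aromatic carbon. Within the data shown here, the one measured step at this position stayed within the scatter, and it is the only guide available. Compound 3 is therefore expected to show a step of a 1.0-fold lower number from compound 2 to compound 3 (0.00 log units; within the scatter), nothing beyond the scatter in either direction. The estimate for compound 3 is 3000 nM, with a range from 1500 nM to 6500 nM.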

Compound 3, concentration for 50% growth inhibition: 3070 nM
Estimate against measurement, compound 3: 1.0-fold (0.01 log units) below; measured number inside the range.
By their numbers in this assay, from the lowest: compounds 2, 3 and 1 (each within the scatter of the next).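

In this assay, the change from 4-fluorophenyl to 4-methoxyphenyl gives a 1.0-fold higher number from compound 2 to compound 3 (0.01 log units; within the scatter), and methoxy in place of methyl gives a 1.0-fold lower number from compound 1 to compound 3 (0.01 log units; within the scatter). Within the data shown here, the position para to a large group now carries three different substituents, methyl, fluoro and methoxy, and each pair stands within the scatter, whereas the earlier compounds offered only one comparison. Across these three compounds, the read-out therefore does not separate the substituents, and methoxy adds no exception to that picture. No evidence at hand bears on this result.

Going by these compounds, it remains open whether an amine, a carboxylic acid or a longer chain such as butoxy at this place would move the number beyond the scatter. On these data alone, it also remains open whether the same picture would hold with a change elsewhere on the shared core.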